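The source may hold more compounds than are shown below. What is called first, only, known or untested is meant among the compounds shown, and "the series" means these compounds.

In a functional assay on T98G cells (Homo sapiens) for inhibition, read by colorimetric assay and MTT assay, with a stated time of 72 h (on this read-out higher numbers stand for weaker inhibition and lower numbers for stronger inhibition), compound 1 (`C=CCCCCOc1ncc(-c2ccccc2OC)n1C`) gives 5000 nM and compound 2 (`C=CCCCCOc1ncc(-c2cc(C(C)C)ccc2OC)n1C`) gives 6000 nM. Compound 2 therefore stands within the scatter of compound 1, so the two cannot be ranked. Compound 3 (`C=CCCCCOc1ncc(-c2cc(Cl)ccc2OC)n1C`) has chloro in place of isopropyl on an aromatic carbon, para to a methoxy group: chloro in place of isopropyl on an aromatic carbon. For the measured compounds named here, only one measured step bears on this change. Putting isopropyl in place of hydrogen gave a 1.2-fold higher number from compound 1 to compound 2 (0.08 log units; within the scatter). This step involves no chloro, so it offers only indirect guidance, and a single pair is thin evidence. Even so, with that step so small, no change beyond the scatter is expected in this assay. The estimated step is a 1.2-fold lower number from compound 2 to compound 3 (0.08 log units; within the scatter). For compound 3 the expected value is 5000 nM, with an estimated range of 2000 nM to 12000 nM.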

Compound 3, half-maximal inhibitory concentration: 48000 nM
Beside the measured number, compound 3's estimate is 9.6-fold (0.98 log units) below it; the measured number lies above the stated range.
By their numbers in this assay, from the lowest: compounds 1 and 2 (each within the scatter of the next); then compound 3.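

At this position, para to a methoxy group, the substituent can matter: in this assay, chloro in place of isopropyl gives an 8.0-fold higher number from compound 2 to compound 3 (0.90 log units; beyond the scatter), and chloro in place of hydrogen gives a 9.6-fold higher number from compound 1 to compound 3 (0.98 log units; beyond the scatter), so compound 3 shows the weakest inhibition of the three. Losing the isopropyl does not by itself account for this shift, since compound 1 also lacks that group yet stands within the scatter of compound 2. Nothing available explains why chloro behaves differently here.

Going by these compounds, whether this weakening is particular to chloro remains open, and fluoro, methyl or an amine at the same position would help to answer that. It is also unclear whether the same change would weaken inhibition with a different chain on the shared core.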